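The source may hold more compounds than are shown below. What is called first, only, known or untested is meant among the compounds shown, and "the series" means these compounds.

Compound 1, `COCn1c(CC(COCc2ccccc2)COCc2ccccc2)c(C)c(=O)[nH]c1=O`, has in a functional assay on HepG2 cells (Homo sapiens) for antiproliferative activity, read by MTT assay, with a stated time of 72 h (on this read-out higher numbers stand for weaker inhibition and lower numbers for stronger inhibition), only the entry "not determined" (no result reported), so no result is recorded for compound 1 in this assay. Compound 2, `Cc1c(CC(O)COCc2ccccc2)[nH]c(=O)[nH]c1=O`, does have an entry in this assay. In this assay compound 2 gives > 100000 nM, which is a limit of the assay rather than a number. Compound 3, `Cc1c(CC(O)COCc2ccccc2)n(COCC[Si](C)(C)C)c(=O)[nH]c1=O`, carries a group of 8 heavy atoms (6 carbon, 1 oxygen, 1 silicon; no ring) in place of a hydrogen atom on an aromatic nitrogen. In this assay compound 3 gives > 100000 nM, again a limit and not a number. The step that the two limits leave unreadable from compound 2 to compound 3 therefore cannot be sized. Compound 3 thus stands at the limit of > 100000 nM in this assay, at which 2 of the 3 values shown sit, with no numbered value around it to compare against.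

Compound 4, `COCn1c(CC(O)COCc2ccccc2)c(C)c(=O)[nH]c1=O`, differs from compound 3 by a hydrogen atom in place of a group of 5 heavy atoms (4 carbon, 1 silicon; no ring), on a saturated chain carbon bound to an oxygen on a saturated carbon. Among the measured compounds shown here, the only measured step between these compounds is unreadable, so no direction and no size can be taken from it. The expectation for compound 4 is thus a further limit rather than a shift beyond the scatter, with the step that the limit leaves unreadable from compound 3 to compound 4 expected to be close to nothing. Compound 4 is estimated at 150000 nM, with a range from 50000 nM to 500000 nM.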

Compound 4, half-maximal inhibitory concentration: > 100000 nM
Compound 4 ended at the assay's limit; the forecaster's own chance of this, stated with the estimate: 85%; the middle value lies beyond the limit too.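

Compound 2, compound 3 and compound 4 each end at a limit of this assay rather than a number, so the steps among them cannot be read: the limit of > 100000 nM in this assay, at which 3 of the 4 values shown sit.

The compounds shown leave open whether any change to the shared core would give a numbered value in this assay.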